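Chlorophenyl amide thioesters: growth inhibition notes

The source may report more compounds than this note shows. Statements on the series, on what has been measured and on what is new or still open speak of the compounds shown alone.

Compound 1 `CC(=O)SCCC(CCCCC(=O)Nc1cccc(Cl)c1)SC(C)=O` and compound 2 `CC(=O)SCCC(CCCCC(=O)Nc1ccc(Cl)cc1)SC(C)=O` share one core. In a functional assay on NCI-H460 cells (Homo sapiens) for inhibition, read by MTT assay, with a stated time of 24 h, tested at 100 ug/mL (a lower number here means less inhibition of growth, a higher number more inhibition of growth at the concentration tested), compound 1 gives 42.8%, and compound 2 gives 47.3%. The change 4-chlorophenyl in place of 3-chlorophenyl on an amide-type nitrogen gave a number 4.5 percentage points higher from compound 1 to compound 2 (within the scatter). Compound 3 `O=C(CCCCC(CCSC(=O)c1ccccc1)SC(=O)c1ccccc1)Nc1cccc(Cl)c1` has a different core; the difference between the two cores is not broken down here. In this assay compound 3 is reported as "not active" (no number reported), and no number is given. Compound 4 `O=C(CCCCC(CCSC(=O)c1ccccc1)SC(=O)c1ccccc1)Nc1ccc(Cl)cc1` is related to compound 3 by 4-chlorophenyl in place of 3-chlorophenyl on an amide-type nitrogen, the same change as between compound 1 and compound 2, at the same place. Because that change gave only a number 4.5 percentage points higher from compound 1 to compound 2 (within the scatter), a step of similar small size is expected here, starting from a compound with no measurable inhibition. Compound 4 is therefore expected to remain weak, estimated at 10% within a range from 0% to 30%.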

Compound 4, percent growth inhibition at one concentration: "not active" (no number reported)
For compound 4 the study gives words and no number; no gap can be computed for the estimate.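

Compound 3 and compound 4 carry no number in this assay, and no step can be read between them. Nothing shown accounts for this result. The compounds shown leave open which feature separating the core of compound 1 from that of compound 3 goes with the loss of a reported number.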